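The source may report more compounds than this note shows. Statements on the series, on what has been measured and on what is new or still open speak of the compounds shown alone.

Compound 1 `CC(=O)c1cccc(-c2ccc(C(=O)N(Cc3cccc(OCCCCCC(=O)O)c3)C(C)C)cc2)c1` gives in an ADME assay on Raji cells (Homo sapiens) for cytotoxicity, read by CellTiter-Glo and resazurin assay, with a stated time of 72 h (on this read-out higher numbers stand for an effect only at larger amounts of compound and lower numbers for an effect already at smaller amounts), a value of > 26000 nM, which is a limit of the assay and not a number.
Compound 2 `CC(C)N(Cc1cccc(OCCCCCC(=O)O)c1)C(=O)c1ccc(-c2cccc(OCc3ccccc3)c2)cc1` gives in this assay a value of > 26000 nM, again a limit and not a number.
Compound 3 `Cc1nnc(-c2cccc(-c3ccc(C(=O)N(Cc4cccc(OCCCCCC(=O)O)c4)C(C)C)cc3)c2)o1` gives in this assay a value of > 26000 nM, also a limit and not a number.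

For the measured compounds named here, compound 3 therefore stands nowhere apart from the other two: all three values sit at the limit of > 26000 nM in this assay, at which 3 of the 3 values shown sit, so no compound can be ranked against another. The three measured steps reflect this. From compound 1 to compound 3 the step is a step that the two limits leave unreadable from compound 1 to compound 3, from compound 2 to compound 3 it is a step that the two limits leave unreadable from compound 2 to compound 3, and from compound 1 to compound 2 it is a step that the two limits leave unreadable from compound 1 to compound 2. None of them gives a size or a direction.

Compound 4 `CC(C)N(Cc1cccc(OCCCCCC(=O)O)c1)C(=O)c1ccc(-c2cccc(Br)c2)cc1` is the next variation on the same core. The change from compound 3 is bromo in place of 5-methyl-1,3,4-oxadiazol-2-yl on an aromatic carbon. Going by the values given here, every measured step at this position on the ring was left unreadable by the limits, so no measured step points to a readable change here either. The step from compound 3 to compound 4 in this assay is expected to be a step that the limit leaves unreadable from compound 3 to compound 4. Compound 4 is estimated to give 30000 nM in this assay, within a range from 12000 nM to 80000 nM, most likely reported as a limit once more.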

Compound 4, half-maximal effective concentration: > 26000 nM
Compound 4: a limit, no number (the forecaster's own chance of this, stated with the estimate: 80%); the middle value is on the limit's open side.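

Compound 4 also gives a limit and not a number in this assay, so its steps from compound 1, compound 2 and compound 3 cannot be read: the limit of > 26000 nM in this assay, at which 4 of the 4 values shown sit.

The compounds shown leave open how these four rank against one another in this assay and whether any group at this place on the ring brings an effect at smaller amounts.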